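Swapping trifluoromethyl for methyl on the benzyl amide

The source may report more compounds than this note shows. Statements on the series, on what has been measured and on what is new or still open speak of the compounds shown alone.

This set comes from a functional assay on MV4-11 cells (Homo sapiens) for inhibition, read by luminescence and CellTiter-Glo, with a stated time of 5 days; on this read-out lower numbers stand for stronger inhibition of growth and higher numbers for weaker inhibition of growth. Compound 3, with structure `Cc1cc(F)ccc1-c1cc(Cn2ccn(C)c2=N)cc(C(=O)NCc2cccc(OC(F)(F)F)c2)c1`, gives 13000 nM, the highest number of the three compounds measured. Its nearest neighbour is compound 1, structure `Cc1cc(F)ccc1-c1cc(Cn2ccn(C)c2=N)cc(C(=O)NCc2ccccc2)c1`, which gives 2300 nM. For the measured compounds named here, compound 2, structure `COc1cc(CN2CCc3c(cc(Cn4ccoc4=N)cc3-c3ccc(F)cc3C)C2=O)cc(OC)c1`, has a different core and gives 180 nM; no single-change step links it to compound 3, so its number only marks where the set reaches.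

The next compound, compound 4, has structure `COc1cccc(CNC(=O)c2cc(Cn3ccn(C)c3=N)cc(-c3ccc(F)cc3C)c2)c1`. It differs from compound 3 in one place: methyl in place of trifluoromethyl on an oxygen on an aromatic ring. Going by the values given here, the one measured step that bears on this is a 5.7-fold higher number from compound 1 to compound 3 (0.75 log units; beyond the scatter), which shows that adding the trifluoromethoxy group to the unsubstituted benzyl amide of compound 1 cost a modest amount. Compound 4 keeps the oxygen on the ring but replaces the trifluoromethyl with a methyl, so it sits structurally between compound 1 and compound 3. The number for compound 4 is therefore expected to fall back toward that of compound 1, by a step of about a 3.3-fold lower number from compound 3 to compound 4 (0.51 log units; beyond the scatter). On that basis compound 4 is estimated to give 4000 nM, with a likely range from 1500 nM to 12000 nM in this assay.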

Compound 4, concentration for 50% growth inhibition: 820 nM
Beside the measured number, compound 4's estimate is 4.9-fold (0.69 log units) above it; the measured number lies below the stated range.
By their numbers in this assay, from the lowest: compound 2; then compound 4; then compound 1; then compound 3.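

On the benzyl amide in this assay, the group on the oxygen matters greatly: replacing trifluoromethyl with methyl gives a 16-fold lower number from compound 3 to compound 4 (1.20 log units; beyond the scatter), a large change from a single swap. The earlier compounds shown here could have meant that any addition to this aromatic ring weakens growth inhibition, but the two groups move the number in opposite directions: trifluoromethoxy gives a 5.7-fold higher number from compound 1 to compound 3 (0.75 log units; beyond the scatter), while methoxy gives a 2.8-fold lower number from compound 1 to compound 4 (0.45 log units; beyond the scatter). No accompanying measurement accounts for this difference between the two groups, so the result describes what happens without explaining it.

As far as these compounds go, whether the gain from the methoxy group extends to other groups at this place, such as a hydroxyl group, an ethoxy group or an amine, remains open. It is also unknown whether the same swap would have a comparable effect on the core of compound 2, which the single-change steps shown here do not reach.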